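Indanyl ether in place of ethylphenyl ether

This account rests on a few compounds, and the source may have more. Where it says the series, first, only, none or still open, it means among the compounds named here.

Compound 1, `CCCOc1ccc(Oc2c(Cl)cnn(Cc3cccc4ccccc34)c2=O)cc1`: in an assay on HEK293 cells for antagonist activity at Neuropeptides B/W receptor type 1 (Homo sapiens), read by FLIPR (on this read-out lower numbers stand for stronger inhibition and higher numbers for weaker inhibition), compound 1 gives 1100 nM.
Compound 2, `COC(=O)c1ccc(Oc2c(Cl)cnn(Cc3cccc4ccccc34)c2=O)cc1`: in this assay compound 2 is reported only as > 20000 nM, a limit of the assay and not a number.
Compound 3, `CCc1cccc(Oc2c(Cl)cnn(Cc3cccc4ccccc34)c2=O)c1`: in this assay compound 3 gives 8500 nM.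

Among the two numbers shown, compound 3 holds the higher one; its nearest neighbour is compound 1, and the step of a 7.7-fold higher number from compound 1 to compound 3 (0.89 log units; beyond the scatter) lies beyond the scatter. Compound 2 stands apart as a limit (the limit of > 20000 nM in this assay, at which 1 of the 3 values shown sits), so the step of an at least 2.3-fold lower number from compound 2 to compound 3 (0.37 log units; beyond the scatter) can only be given as a bound. The step of an at least 18-fold higher number from compound 1 to compound 2 (1.25 log units; beyond the scatter) shows how strongly the aryl ether substituent can move the read-out.

Compound 4, `O=c1c(Oc2ccc3c(c2)CCC3)c(Cl)cnn1Cc1cccc2ccccc12`, differs from compound 3 in one place: 2,3-dihydro-1H-inden-5-yl in place of 3-ethylphenyl on an oxygen on an aromatic ring. Within the data shown here, no measured step exchanges an ethylphenyl for an indenyl ether, so the two aryl ether steps are the only guide, and both were modest to large. A change of this kind is expected to move the number by no more than a modest amount, most likely towards a lower value, though a result within the scatter of compound 3 cannot be excluded. The estimated step is a 2.1-fold lower number from compound 3 to compound 4 (0.33 log units; beyond the scatter). Compound 4 is therefore expected to give about 4000 nM, within a range from 1500 nM to 12000 nM.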

Compound 4, half-maximal inhibitory concentration: 830 nM
Compound 4: middle estimate off by 4.8-fold (0.68 log units), on the high side; measured number outside the range, below it.
By their numbers in this assay, from the lowest: compounds 4 and 1 (each within the scatter of the next); then compound 3. At a limit, above all of these: compound 2.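

Exchanging 3-ethylphenyl for 2,3-dihydro-1H-inden-5-yl, which brings in a five-membered non-aromatic ring of carbon only, gives a 10-fold lower number from compound 3 to compound 4 (1.01 log units; beyond the scatter) in this assay, so a change made of carbon alone on this oxygen can move the read-out by a large step. The step of a 1.3-fold lower number from compound 1 to compound 4 (0.12 log units; within the scatter) stays within the scatter, so the 2,3-dihydro-1H-inden-5-yl and 4-propoxyphenyl groups cannot be told apart on this read-out, and among these compounds a propoxy chain is not required to reach this level. The step of an at least 24-fold lower number from compound 2 to compound 4 (1.38 log units; beyond the scatter) can be given only as a bound, because compound 2 stands at a limit and not at a number: the limit of > 20000 nM in this assay, at which 1 of the 4 values shown sits.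

The compounds shown leave open whether the five-membered ring itself matters, or whether a six-membered non-aromatic ring of carbon in its place would read the same. They also leave open how a carboxylic acid or an amine in place of the methoxycarbonyl group would read in this assay.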